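Swapping morpholin-4-yl for 3-hydroxypiperidin-1-yl on a sulfonyl sulfur

The source may hold more compounds than are shown below. What is called first, only, known or untested is meant among the compounds shown, and "the series" means these compounds.

Among the compounds with values here, in a functional assay on A2780 cells (Homo sapiens) for cytotoxicity, read by sulforhodamine B assay, with a stated time of 72 h (on this read-out lower numbers stand for stronger inhibition and higher numbers for weaker inhibition), compound 1 `O=C(NCc1ccc(S(=O)(=O)c2cccc(C(F)(F)F)c2)cc1)N1Cc2ccncc2C1` gives 2.7 nM and compound 2 `O=C(NCc1ccc(S(=O)(=O)N2CCOCC2)cc1)N1Cc2ccncc2C1` gives 68 nM as the higher of the two numbers so far. Compound 3 `O=C(NCc1ccc(S(=O)(=O)N2CCC[C@H](O)C2)cc1)N1Cc2ccncc2C1` is still unmeasured and differs from compound 2 in one place, on a sulfonyl sulfur whose other neighbour is an aromatic carbon, where 3-hydroxypiperidin-1-yl stands in place of morpholin-4-yl 3-hydroxypiperidin-1-yl in place of morpholin-4-yl on a sulfonyl sulfur and the rest is unchanged. Within the data shown here, the only measured step at that sulfur is a 25-fold higher number from compound 1 to compound 2 (1.40 log units; beyond the scatter) on going from 3-(trifluoromethyl)phenyl to morpholin-4-yl, so a change there can move the number by a large amount. Among the measured compounds shown here, that step removed an aromatic group, whereas here one six-membered non-aromatic ring follows another, and no measured pair tests a hydroxy group. The expectation therefore starts from compound 2 at 68 nM and allows only a small shift towards a lower number, with no step beyond the scatter expected. The estimate implies a 1.5-fold lower number from compound 2 to compound 3 (0.18 log units; within the scatter) as the expected step. In this assay compound 3 is estimated at 45 nM within an expected range of 14 nM to 140 nM for this measurement.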

Compound 3, half-maximal inhibitory concentration: 150 nM
Estimate against measurement, compound 3: 3.3-fold (0.52 log units) below; the whole stated range lies below it.
By their numbers in this assay, from the lowest: compound 1; then compound 2; then compound 3.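

In this assay, the exchange of one six-membered non-aromatic ring for another on the sulfonyl sulfur is not neutral: it gives a 2.2-fold higher number from compound 2 to compound 3 (0.34 log units; beyond the scatter), a modest step but one that is readable beyond the scatter. The position therefore responds not only to the loss of the aromatic group but also to a change among non-aromatic rings, and here the entry of 3-hydroxypiperidin-1-yl goes with the higher number. With a 56-fold higher number from compound 1 to compound 3 (1.74 log units; beyond the scatter), the second non-aromatic ring also stands far from the 3-(trifluoromethyl)phenyl compound, although nothing available accounts for the order of the three numbers.

The compounds shown leave open whether the step from morpholin-4-yl follows the hydroxy group, the loss of the ring oxygen or the defined stereocentre, and a plain piperidin-1-yl or the opposite stereoisomer of 3-hydroxypiperidin-1-yl on the same sulfur would separate these. They also leave open how much of the large gap to compound 1 rests on the aromatic ring and how much on its trifluoromethyl group, a question that a plain phenyl at this sulfur would address.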